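This account rests on a few compounds, and the source may have more. Where it says the series, first, only, none or still open, it means among the compounds named here.

Compound 1 `COc1ccc(C2N=C(SCc3ccccc3)NC(C)=C2C(=O)Nc2ccc(F)cc2)cc1OC` is the starting point. In a functional assay on the whole organism (artery, strain albino) with Rattus norvegicus as the target, with a stated time of 600 min, at a dose of 10 mg/kg by the oral route (on this read-out higher numbers stand for more inhibition at the one dose given (going by the name of the read-out) and lower numbers for less inhibition), compound 1 gives 3.1%. Compound 2 `COc1ccc(C2N=C(SCc3cccc(Cl)c3)NC(C)=C2C(=O)Nc2ccc(F)cc2)cc1OC` carries one change, (chloro in place of hydrogen on an aromatic carbon), and in this assay compound 2 gives 17.4%, a step of a number 14.3 percentage points higher from compound 1 to compound 2 (beyond the scatter).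

Compound 3 `CC1=C(C(=O)Nc2ccc(Br)cc2)C(c2ccc(Cl)cc2Cl)N=C(SCc2ccccc2)N1` has a different core; the difference between the two cores is not broken down here. In this assay compound 3 gives 17.4%, the same figure as compound 2 at the digits printed.

Compound 4 `CC1=C(C(=O)Nc2ccc(Br)cc2)C(c2ccc(Cl)cc2Cl)N=C(SCc2ccccc2Cl)N1`, not yet measured, arises from compound 3 by chloro in place of hydrogen on an aromatic carbon. Going by the values given here, this is the same kind of change as the one from compound 1 to compound 2, but the place differs: there the chloro sits meta to a large group, here ortho to a large group. Because the earlier step was a number 14.3 percentage points higher from compound 1 to compound 2 (beyond the scatter), a smaller rise is expected here, a step of a number 7.6 percentage points higher from compound 3 to compound 4 (within the scatter), since the place is not the same. Compound 4 is therefore estimated at 25%, between 10% and 42%.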

Compound 4, a percentage reported as inhibition, in the whole organism at one dose (the size of the read-out at that dose, not a potency): 24.6%
The estimate for compound 4 lay 0.4 percentage points above the measured number, and the stated range covers the measured number.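

In this assay, the chloro on the benzyl group gives a number 7.2 percentage points higher from compound 3 to compound 4 (within the scatter), a step too small on its own to be told from no change. Set beside the earlier step, the two results cannot be told apart: the same change on two cores in this assay, a number 14.3 percentage points higher (beyond the scatter) from compound 1 to compound 2 and a number 7.2 percentage points higher (within the scatter) from compound 3 to compound 4, 7.1 percentage points apart, within the scatter of two such steps. The change may therefore carry over from one core to the other, but this is not shown, as the chloro sits in a different place in each pair and there are only two pairs.

The compounds shown leave open what the chloro would do in the same place on both cores. They also leave open how an amine or a carboxylic acid on the benzyl ring would compare with the chloro.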